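The compounds below may be only part of what the source reports. "The series", "measured", "known", "first", "only" and "open" are said of these compounds alone.

Measured in a functional assay on HepG2 cells (Homo sapiens) for inhibition, read by MTT assay, with a stated time of 3 days; on this read-out higher numbers stand for weaker inhibition and lower numbers for stronger inhibition:
- compound 1 `CC[C@H](C)[C@H](NCC(=O)NNC(=O)COc1ccc(-c2nc3ccccc3s2)cc1OC)C(=O)O`: 3540 nM
- compound 2 `CCOC(=O)[C@@H](NCC(=O)NNC(=O)COc1ccc(-c2nc3ccccc3s2)cc1OC)[C@@H](C)CC`: 3460 nM
- compound 3 `CCOC(=O)[C@H](CCCNC(=N)NCC(=O)NNC(=O)COc1ccc(-c2nc3ccccc3s2)cc1OC)N[N+](=O)[O-]`: 3730 nM

Compound 2 lies within the scatter of both compound 1 and compound 3, so the three cannot be ranked. Compound 4 `CCOC(=O)[C@@H]1CCCN1CC(=O)NNC(=O)COc1ccc(-c2nc3ccccc3s2)cc1OC` follows from compound 2 by 2-(ethoxycarbonyl)pyrrolidin-1-yl in place of (1-(ethoxycarbonyl)-2-methylbutyl)amino on a saturated chain carbon bound to a carbonyl carbon, that is, 2-(ethoxycarbonyl)pyrrolidin-1-yl in place of (1-(ethoxycarbonyl)-2-methylbutyl)amino. Within the data shown here, no measured step makes this exchange. The only one, a 1.0-fold lower number from compound 1 to compound 2 (0.01 log units; within the scatter), changes another place and bears on it only indirectly. Compound 3, with a different chain at this place, gives 3730 nM, within the scatter of compound 2. An estimated step of a 1.0-fold higher number from compound 2 to compound 4 (0.00 log units; within the scatter) is therefore expected, with no direction beyond the scatter. The expected value for compound 4 is 3500 nM, with an estimated range from 1700 nM to 7000 nM.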

Compound 4, half-maximal inhibitory concentration: 2800 nM
The estimate for compound 4 lay 1.3-fold (0.10 log units) above the measured number; measured number inside the range.
By their numbers in this assay, from the lowest: compounds 4, 2, 1 and 3 (each within the scatter of the next).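

In this assay the ring-bearing 2-(ethoxycarbonyl)pyrrolidin-1-yl on a saturated chain carbon bound to a carbonyl carbon gives a 1.2-fold lower number from compound 2 to compound 4 (0.09 log units; within the scatter) and a 1.3-fold lower number from compound 1 to compound 4 (0.10 log units; within the scatter). This position therefore accepts a ring in place of the open chains, and an entering group without a hydrogen-bond donor, with no step beyond the scatter. Nothing available explains why these numbers stay so close. On these data alone, whether a piperidine ring or a free carboxylic acid in place of the ethyl ester would move the number beyond the scatter remains open.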